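A few compounds are considered here, and "the series" means these few. Any claim that something is new, unique, unknown or untested is made for them only; others in the source may bear on it.

Compounds measured in a functional assay on SW-620 cells (Homo sapiens) for antiproliferative activity, read by MTT assay, with a stated time of 24 h; a higher number here means a weaker inhibitor, a lower number a stronger inhibitor:
- compound 1 `CCN(CC)c1ccc(/C=C/C(=O)c2ccc(OC)c3c2OC(C)(C)C=C3)cc1`: 670 nM
- compound 2 `COc1ccc(C(=O)/C=C/c2ccc(-n3ccnc3)cc2)c2c1C=CC(C)(C)O2`: a limit of the assay, > 10000 nM
- compound 3 `COc1ccc(C(=O)/C=C/c2ccccc2)c2c1C=CC(C)(C)O2`: a limit of the assay, > 10000 nM

Compound 3 stands at the upper limit of this assay, so only a bound is known for it. Compound 1 sits far from that bound, and the step of an at least 14-fold higher number from compound 1 to compound 3 (1.17 log units; beyond the scatter) shows how much is lost when the diethylamino group on the aromatic carbon is replaced by hydrogen. The step that the two limits leave unreadable from compound 2 to compound 3 cannot be read, since both compounds sit at the limit of > 10000 nM in this assay, at which 2 of the 3 values shown sit.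

Compound 4 `COc1ccc(C(=O)/C=C/c2cccc(O)c2)c2c1C=CC(C)(C)O2` differs from compound 3 by hydroxy in place of hydrogen on an aromatic carbon. Among the compounds with values here, no measured step changes this position in the same way: the only substituent steps recorded, from compound 1 to compound 2 and from compound 1 to compound 3, both remove the diethylamino group, and neither introduces a hydroxy group. The comparison of compound 2 with compound 3, both at the limit, gives no direction either.

Within the data shown here, with no step to lean on, compound 4 is expected to remain near the limit, and the step of a number no higher from compound 3 to compound 4 (the limit leaves the size open) is estimated as small. Compound 4 is therefore estimated at 10000 nM, within a range from 3000 nM to 30000 nM, with a strong chance that this assay again reports only a limit.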

Compound 4, half-maximal inhibitory concentration: > 10000 nM
Compound 4: a limit, no number; the forecaster's own chance of this, stated with the estimate: 60%; the middle value sits exactly at the limit.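

Compound 3 and compound 4 both stand at the limit of this assay, so the step between them, hydroxy in place of hydrogen, cannot be read: the limit of > 10000 nM in this assay, at which 3 of the 4 values shown sit. The compounds shown leave open whether going from phenyl to 3-hydroxyphenyl changes the activity in this assay at all, and in which direction.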